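This account rests on a few compounds, and the source may have more. Where it says the series, first, only, none or still open, it means among the compounds named here.

Measured in a functional assay on KB cells (Homo sapiens) for antiproliferative activity, read by sulforhodamine B assay, with a stated time of 3 days; a higher number here means that more compound is needed for the effect, a lower number that less compound is needed:
Compound 1 `CCC1=C(O)c2c(oc(-c3cccc(F)c3)cc2=O)C(CC)(CC)C1=O`: > 56.2 uM, a limit.
Compound 2 `CCC1=C(O)c2c(oc(-c3ccc(O)c(O)c3)cc2=O)C(CC)(CC)C1=O`: 10 uM.

Among the compounds with values here, compound 2 holds the only actual number so far, since the other result is a limit. Compound 3 `CCC1=C(O)c2c(oc(-c3cc(C)ccc3C)cc2=O)C(CC)(CC)C1=O` carries 2,5-dimethylphenyl in place of 3,4-dihydroxyphenyl on an aromatic carbon. Within the data shown here, one measured step bears on this: an at least 5.6-fold lower number from compound 1 to compound 2 (0.74 log units; beyond the scatter), which brought in that same 3,4-dihydroxyphenyl. Compound 3 gives the group up again, so a higher number in this assay is expected. However, 2,5-dimethylphenyl is not 3-fluorophenyl, so the size stays open. The expected change is a 3.0-fold higher number from compound 2 to compound 3 (0.48 log units; beyond the scatter). For compound 3 the estimated value is 30 uM, with a range of 12 uM to 75 uM.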

Compound 3, concentration for half-maximal effect: 14.5 uM
For compound 3 the middle estimate is 2.1-fold (0.32 log units) above the measured one; the range from low to high includes it.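

On the carbon next to the ring oxygen, the hydroxyl groups of 3,4-dihydroxyphenyl prove dispensable: 2,5-dimethylphenyl, with 0 hydrogen-bond donors, gives a 1.5-fold higher number from compound 2 to compound 3 (0.16 log units; within the scatter). The substituted ring that enters also stands apart from 3-fluorophenyl, with an at least 3.8-fold lower number from compound 1 to compound 3 (0.58 log units; beyond the scatter). Compound 1 remains a limit, so that step gives only a minimum size: the limit of > 56.2 uM in this assay, at which 1 of the 3 values shown sits.

The compounds shown leave open which of the two methyl groups matters, or whether both do. As far as these compounds go, how an amine or a carboxylic acid on this phenyl ring would read also remains open.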